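A few compounds are considered here, and "the series" means these few. Any claim that something is new, unique, unknown or untested is made for them only; others in the source may bear on it.

Three compounds have been measured in an assay on isolated protein for inhibition of protein kinase C theta type (Homo sapiens), read by TR-FRET, with a stated time of 2 h; on this read-out lower numbers stand for stronger inhibition and higher numbers for weaker inhibition:

Compound 1 `N#Cc1cnc(NCc2cnccc2C(F)(F)F)cc1N[C@H]1CC[C@H](O)CC1` gives 350 nM
Compound 2 `CO[C@H]1CC[C@@H](Nc2cc(NCc3cnccc3C(F)(F)F)ncc2C#N)CC1` gives 58 nM
Compound 3 `CO[C@H]1CC[C@H](Nc2cc(NCc3cnccc3C(F)(F)F)ncc2C#N)CC1` gives 1100 nM

Compound 1 stands second highest of the three, with compound 2 stronger than it a 6.0-fold lower number from compound 1 to compound 2 (0.78 log units; beyond the scatter) and compound 3 weaker a 3.1-fold higher number from compound 1 to compound 3 (0.50 log units; beyond the scatter). Compound 4 `N#Cc1cnc(NCc2cnccc2C(F)(F)F)cc1NCC1CCOCC1` is not yet measured; it differs from compound 1 in that ((oxan-4-yl)methyl in place of 4-hydroxycyclohexyl on a nitrogen on an aromatic ring). Within the data shown here, two measured steps bear on this. Replacing the hydroxyl hydrogen by a methyl improved the number in one configuration a 6.0-fold lower number from compound 1 to compound 2 (0.78 log units; beyond the scatter) and worsened it in the mirror-image configuration a 3.1-fold higher number from compound 1 to compound 3 (0.50 log units; beyond the scatter), and the gap between those two mirror images was wide a 19-fold higher number from compound 2 to compound 3 (1.28 log units; beyond the scatter) because of the fact that compounds 2 and 3 differ only in the configuration as drawn. In compound 4 the hydroxyl is gone and no stereocentre remains, so neither measured step maps onto it cleanly. A modest step is expected in this assay, with the direction uncertain and leaning weaker, in line with compound 3 1100 nM. Compound 4 is therefore estimated at 550 nM, between 120 nM and 2500 nM, a step of a 1.6-fold higher number from compound 1 to compound 4 (0.20 log units; within the scatter).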

Compound 4, half-maximal inhibitory concentration: 400 nM
Compound 4: the middle estimate sits 1.4-fold (0.14 log units) above what was measured; the range from low to high includes it.
By their numbers in this assay, from the lowest: compound 2; then compounds 1 and 4 (each within the scatter of the next); then compound 3.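

In this assay, (oxan-4-yl)methyl can take the place of 4-hydroxycyclohexyl on this nitrogen with no change beyond the scatter: a 1.1-fold higher number from compound 1 to compound 4 (0.06 log units; within the scatter). The entering group has no hydrogen-bond donor and no defined stereocentre, so neither the hydroxyl hydrogen of compound 1 nor a defined configuration is required to hold a number of this size. Compound 4 also lands inside the spread of the two methoxy compounds, with a 6.9-fold higher number from compound 2 to compound 4 (0.84 log units; beyond the scatter) and a 2.8-fold lower number from compound 3 to compound 4 (0.44 log units; beyond the scatter), a spread that comes from configuration alone: the fact that compounds 2 and 3 differ only in the configuration as drawn.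

Still open, going by these compounds, is which part of the swap matters, as the oxygen moves into the ring and a methyl link appears in one step. A plain cyclohexylmethyl group, or a piperidine ring carrying an amine in place of that oxygen, would help separate these.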